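A few compounds are considered here, and "the series" means these few. Any claim that something is new, unique, unknown or untested is made for them only; others in the source may bear on it.

Measured compounds in this series:
compound 1 `CNS(=O)(=O)c1ccc(-c2cnc(N)c(-c3ccc(OC)nc3)c2)cc1` — 12.5 ug/mL
compound 2 `COc1ccc(-c2cc(-c3ccc(S(N)(=O)=O)cc3)cnc2N)cn1` — 12.5 ug/mL
compound 3 `COc1ccc(-c2cc(-c3ccc(NS(C)(=O)=O)cc3)cnc2N)cn1` — 25 ug/mL

In a physicochemical assay for solubility, read by nephelometry, in phosphate buffer, measured as kinetic solubility, at pH 6.5 (on this read-out lower numbers stand for lower solubility and higher numbers for higher solubility), compound 1 gives 12.5 ug/mL and stands level with compound 2, the two together the lowest of the three numbers; the step of a 2.0-fold higher number from compound 1 to compound 3 (0.30 log units; within the scatter) is the largest gap from compound 1 and still within the scatter. Compound 4 `COc1ccc(-c2cc(-c3ccc(C(N)=O)cc3)cnc2N)cn1` is not yet measured. Its change from compound 1 is carbamoyl in place of methylsulfamoyl on an aromatic carbon.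

Among the compounds with values here, three measured steps bear on the same position. The step of no change at the digits printed from compound 1 to compound 2 (within the scatter) strips the methyl from the sulfonamide nitrogen without effect. The steps of a 2.0-fold higher number from compound 1 to compound 3 (0.30 log units; within the scatter) and a 2.0-fold higher number from compound 2 to compound 3 (0.30 log units; within the scatter) swap the sulfonyl-bearing group for a methanesulfonamido group and also stay within the scatter. Within the data shown here, no measured step replaces the sulfur-containing group by a carbamoyl group, so the direct evidence is absent; what exists shows this position tolerating changes of donor and acceptor count without a shift beyond the scatter.

The expected step of no change at the digits printed from compound 1 to compound 4 (within the scatter) is therefore none beyond the scatter. Compound 4 is expected to give about 12.5 ug/mL, within 6 ug/mL to 30 ug/mL.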

Compound 4, solubility: 12.5 ug/mL
Estimate against measurement, compound 4: no gap at the digits printed, within the range that was stated.
By their numbers in this assay, from the lowest: compounds 1, 2, 4 and 3 (each within the scatter of the next).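

In this assay, carbamoyl on the aromatic carbon para to a large group replaces each sulfur-containing group with the read-out staying within the scatter: the series reads no change at the digits printed from compound 1 to compound 4 (within the scatter) and no change at the digits printed from compound 2 to compound 4 (within the scatter) and also a 2.0-fold lower number from compound 3 to compound 4 (0.30 log units; within the scatter) without any step beyond it. Within the data shown here, the position therefore accepts a group with no sulfur and fewer heavy atoms than methylsulfamoyl, which the earlier compounds, all carrying sulfur at this place, could not show. No measurement in hand explains why these four values lie so close together.

As far as these compounds go, a carboxylic acid, an amine or a longer chain on the carbamoyl nitrogen at this same carbon remains open. The compounds shown also leave open whether this narrow range would hold with any change elsewhere on the shared core.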